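Chloro for methoxy on the aryl of compound 3

The source may hold more compounds than are shown below. What is called first, only, known or untested is meant among the compounds shown, and "the series" means these compounds.

Measured compounds in a functional assay on WM 266-4 cells (Homo sapiens) for antiproliferative activity, read by MTT assay, with a stated time of 24 h; a higher number here means a weaker inhibitor of growth, a lower number a stronger inhibitor of growth:
compound 1 `COc1ccc(C2=NN(C(=O)c3ccc(C)nc3)C(c3ccc(Cl)cc3)C2)cc1`, 890 nM
compound 2 `COc1ccc(C2=NN(C(=O)c3cccnc3Cl)C(c3ccc(OCc4ccccc4)cc3)C2)cc1`, 9150 nM
compound 3 `COc1ccc(C2=NN(C(=O)c3ccc(C)nc3)C(c3ccc(OCc4ccccc4)cc3)C2)cc1`, 7950 nM

Compound 3 stands second highest of the three numbers in this assay. Its nearest neighbour is compound 2, with a step of a 1.2-fold lower number from compound 2 to compound 3 (0.06 log units; within the scatter), and the change at the carbonyl there did not move the number beyond the scatter. The larger gap is to compound 1: the step of an 8.9-fold higher number from compound 1 to compound 3 (0.95 log units; beyond the scatter), benzyloxy in place of chloro on an aromatic carbon, raised the number well beyond the scatter.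

Compound 4 `Cc1ccc(C(=O)N2N=C(c3ccc(Cl)cc3)CC2c2ccc(OCc3ccccc3)cc2)cn1` keeps the benzyloxyphenyl and the 6-methylpyridin-3-yl amide of compound 3 and differs on the other aryl: chloro in place of methoxy on an aromatic carbon. Among the measured compounds shown here, no measured pair touches this position, so neither step above bears on the change directly. Without a comparable step, the working expectation is that the move from compound 3 to compound 4 in this assay stays within the scatter, with a range widened to allow for the absence of a precedent, giving an expected step of a 1.0-fold higher number from compound 3 to compound 4 (0.00 log units; within the scatter).

For compound 4 the estimate in this assay is 8000 nM, expected to fall between 2500 nM and 25000 nM.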

Compound 4, concentration for 50% growth inhibition: 9200 nM
Beside the measured number, compound 4's estimate is 1.2-fold (0.06 log units) below it, and the stated range covers the measured number.
By their numbers in this assay, from the lowest: compound 1; then compounds 3, 2 and 4 (each within the scatter of the next).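

In this assay, the first step read at this position, a 1.2-fold higher number from compound 3 to compound 4 (0.06 log units; within the scatter), shows that 4-methoxyphenyl to 4-chlorophenyl stays within the scatter with the benzyloxyphenyl and the 6-methylpyridin-3-yl amide held fixed. Among the compounds shown, this aryl now joins the carbonyl substituent as a place where a single change stays within the scatter, while the one step beyond the scatter remains the benzyloxy for chloro exchange on the other aryl, an 8.9-fold higher number from compound 1 to compound 3 (0.95 log units; beyond the scatter). Nothing measured here offers an account of the outcome at this position.

Going by these compounds, the reading comes from one pair carrying the benzyloxyphenyl, and whether the same exchange also stays within the scatter with chloro in place of that benzyloxy remains open. How this aryl responds to an amine or a carboxylic acid in place of the methoxy or chloro also remains open, as the compounds shown carry only those two groups here.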